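A few compounds are considered here, and "the series" means these few. Any claim that something is new, unique, unknown or untested is made for them only; others in the source may bear on it.

In a functional assay on B16 cells (Mus musculus) for antiproliferative activity, read by MTT assay, with a stated time of 24 h (on this read-out lower numbers stand for stronger inhibition and higher numbers for weaker inhibition), compound 1 `COc1cc(OC)c(-c2coc3cc(OCc4ccccc4C(F)(F)F)ccc3c2=O)cc1OC` gives 8550 nM, compound 2 `COc1cc(OC)c(-c2coc3cc(OCc4ccc(C#N)cc4)ccc3c2=O)cc1OC` gives 7000 nM, and compound 3 `COc1cc(OC)c(-c2coc3cc(OCc4ccccc4Br)ccc3c2=O)cc1OC` gives 8900 nM. Compound 3 thus stands level with the other two, and its steps to both lie within the scatter.

Next is compound 4 `COc1cc(OC)c(-c2coc3cc(OCc4cccc(C(F)(F)F)c4)ccc3c2=O)cc1OC`, which keeps the shared core. The change from compound 3 is 3-(trifluoromethyl)phenyl in place of 2-bromophenyl on a saturated chain carbon bound to an oxygen on an aromatic ring.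

The closest measured change is a 1.0-fold higher number from compound 1 to compound 3 (0.02 log units; within the scatter), with bromo in place of trifluoromethyl on an aromatic carbon. Exchanges of the whole aryl group at this place give a 1.2-fold lower number from compound 1 to compound 2 (0.09 log units; within the scatter) and a 1.3-fold higher number from compound 2 to compound 3 (0.10 log units; within the scatter). Within the data shown here, no measured compound carries 3-(trifluoromethyl)phenyl, so the read-across is limited. With all three steps inside the scatter, no step beyond the scatter is expected in this assay.

The expected step is a 1.1-fold lower number from compound 3 to compound 4 (0.05 log units; within the scatter). Compound 4 is estimated at 8000 nM, with an expected range of 4000 nM to 16000 nM.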

Compound 4, half-maximal inhibitory concentration: > 10000 nM
Compound 4: a limit, no number; the forecaster's own chance of this, stated with the estimate: 5%; middle value at least 1.2-fold (0.09 log units) from the limit.
By their numbers in this assay, from the lowest: compounds 2, 1 and 3 (each within the scatter of the next). At a limit, above all of these: compound 4.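

Compound 4 gives a limit rather than a number in this assay, and it is the only compound shown to do so: the limit of > 10000 nM in this assay, at which 1 of the 4 values shown sits. As floors, an at least 1.1-fold higher number from compound 3 to compound 4 (0.05 log units; that floor lies within the scatter), an at least 1.4-fold higher number from compound 2 to compound 4 (0.15 log units; that floor lies within the scatter) and an at least 1.1-fold higher number from compound 1 to compound 4 (0.06 log units; that floor lies within the scatter) each remain within the scatter, so the exchange of 2-bromophenyl, 4-cyanophenyl or 2-(trifluoromethyl)phenyl for 3-(trifluoromethyl)phenyl is not shown to change the result, and the true size of each step cannot be read. The new information is therefore narrow: a fourth aryl group at this place, on a saturated chain carbon bound to an oxygen on an aromatic ring, still gives no step shown to lie beyond the scatter.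

As far as these compounds go, how far compound 4 actually lies from compounds 1, 2 and 3 stays open. Also open, from the compounds shown here alone, is whether an amine or a carboxylic acid on this aryl group, or a longer chain in place of the single saturated carbon, would give a step beyond the scatter.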